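Methyl for Trifluoromethyl on a Fluorinated Sulfonyl Aryl

The compounds below may be only part of what the source reports. "The series", "measured", "known", "first", "only" and "open" are said of these compounds alone.

Measured compounds in an ADME assay on microsomes from liver (Mus musculus), read by LC-MS, using NADPH, tested at 10 uM; a lower number here means that the liver removes a smaller share, a higher number that the liver removes a larger share of the compound in one pass:
compound 1 `O=C(NCc1ccc(F)cc1)c1ccc(N2CCN(S(=O)(=O)c3ccccc3C(F)(F)F)CC2)nn1`: compound 1 gives 0.66
compound 2 `Cc1ccccc1S(=O)(=O)N1CCN(c2ccc(C(=O)NCc3ccc(F)cc3)nn2)CC1`: compound 2 gives 0.7
compound 3 `O=C(NCc1ccc(F)cc1)c1ccc(N2CCN(S(=O)(=O)c3ccc(F)cc3C(F)(F)F)CC2)nn1`: compound 3 gives 0.84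

Compound 4 `Cc1cc(F)ccc1S(=O)(=O)N1CCN(c2ccc(C(=O)NCc3ccc(F)cc3)nn2)CC1` has not been measured. It differs from compound 3 by methyl in place of trifluoromethyl on an aromatic carbon. The same kind of change, (methyl in place of trifluoromethyl on an aromatic carbon), separates compound 1 from compound 2, where the place is ortho to a large group only, without a fluoro group meta to it; that step was a number 0.040 higher from compound 1 to compound 2 (within the scatter). The two cores differ by fluoro in place of hydrogen on an aromatic carbon.

Because the step a number 0.040 higher from compound 1 to compound 2 (within the scatter) lay within the scatter, the same kind of change is expected to move compound 3 only slightly, and the step to compound 4 is estimated at a number 0.030 higher from compound 3 to compound 4 (within the scatter). Compound 4 is therefore expected to give about 0.87, with a likely range from 0.76 to 0.95.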

Compound 4, hepatic extraction ratio: 0.8
Compound 4: the middle estimate sits 0.070 above what was measured; low and high end bracket the measured number.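

In this assay, methyl in place of trifluoromethyl gave a number 0.040 lower from compound 3 to compound 4 (within the scatter), so the change carried from one core to the other without a difference beyond the scatter: the same change on two cores in this assay, a number 0.040 higher (within the scatter) from compound 1 to compound 2 and a number 0.040 lower (within the scatter) from compound 3 to compound 4, 0.080 apart, within the scatter of two such steps. Fluoro in place of hydrogen, at a number 0.10 higher from compound 2 to compound 4 (within the scatter), also carried over between its two cores: the same change on two cores in this assay, a number 0.18 higher (beyond the scatter) from compound 1 to compound 3 and a number 0.10 higher (within the scatter) from compound 2 to compound 4, 0.080 apart, within the scatter of two such steps. Going by these compounds alone, both changes together gave a number 0.14 higher from compound 1 to compound 4 (beyond the scatter), but these are only two cores and small steps, so the agreement neither shows that the changes carry over more widely nor excludes a small real difference between the cores.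

From the compounds shown here alone, whether chloro or methoxy would behave as methyl does on the sulfonyl aryl remains open. So does whether either change carries over to a core bearing an amine or a carboxylic acid.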